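Shortening the Ester Chain of an Inactive Glycoside

This account rests on a few compounds, and the source may have more. Where it says the series, first, only, none or still open, it means among the compounds named here.

Compound 1 `C/C=C1/[C@H](O[C@@H]2O[C@H](COC(C)=O)[C@@H](OC(C)=O)[C@H](OC(C)=O)[C@H]2OC(C)=O)OC=C(C(=O)O)[C@H]1CC(=O)OC`: in a functional assay on SK-BR-3 cells (Homo sapiens) for antiproliferative activity, read by MTT assay, with a stated time of 72 h (a lower number here means a stronger inhibitor, a higher number a weaker inhibitor), compound 1 gives > 20000 nM
Compound 2 `C/C=C1/[C@H](O[C@@H]2O[C@H](CO)[C@@H](O)[C@H](O)[C@H]2O)OC=C(C(=O)OC)[C@H]1CC(=O)OCCc1ccc(OC)c(OC)c1`: in this assay compound 2 gives > 15000 nM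

Both entries are limits of this assay rather than numbers. Compound 2 stands at the limit of > 15000 nM in this assay, at which 1 of the 2 values shown sits, so its place relative to compound 1 cannot be ranked. Compound 1 sits at the limit of > 20000 nM in this assay, at which 1 of the 2 values shown sits, in this assay. Compound 3 `C/C=C1/[C@H](O[C@@H]2O[C@H](CO)[C@@H](O)[C@H](O)[C@H]2O)OC=C(C(=O)OC)[C@H]1CC(=O)OCc1ccc(OC)c(OC)c1` is the next member; it differs from compound 2 by 3,4-dimethoxyphenyl in place of 3,4-dimethoxybenzyl on a saturated chain carbon bound to an oxygen next to a carbonyl group.

For the measured compounds named here, no step between two measured compounds is available, so the size of such a change in this assay is unknown from these data. Since compound 2 itself reaches only a limit, compound 3 is expected to stay at or near a limit too, with a step that the limit leaves unreadable from compound 2 to compound 3 expected to lie within the scatter. In this assay compound 3 is therefore estimated near 20000 nM, most likely between 8000 nM and 60000 nM.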

Compound 3, half-maximal inhibitory concentration: > 15000 nM
Compound 3: no number, only a limit; the forecaster's own chance of this, stated with the estimate: 80%; the middle value is on the limit's open side.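

In this assay compound 3 gives > 15000 nM, a limit and not a number. For the compounds shown here, compound 2 also stands at a limit, so no step from compound 2 to compound 3 can be read. The compounds shown leave open whether shortening this ester chain changes activity at all.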